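The source may hold more compounds than are shown below. What is called first, only, known or untested is meant among the compounds shown, and "the series" means these compounds.

Measured compounds:
compound 1 `COc1ccc(-n2cc(NC(=O)c3ccc(NS(=O)(=O)c4ccccc4)cc3)cn2)cc1` — in a functional assay on HepG2 cells (Homo sapiens) for inhibition, read by MTT assay, with a stated time of 48 h (a lower number here means a stronger inhibitor, a higher number a weaker inhibitor), compound 1 gives 57300 nM
compound 2 `COc1cccc(-n2cc(NC(=O)c3ccc(NS(=O)(=O)c4ccccc4)cc3)cn2)c1` — in this assay compound 2 gives 64200 nM

Compound 1 holds the lowest of the two numbers recorded in this assay, yet its nearest neighbour, compound 2, sits within the scatter: a 1.1-fold higher number from compound 1 to compound 2 (0.05 log units; within the scatter). That single step concerns the methoxyphenyl on the aromatic nitrogen and leaves the sulfonyl side of the shared core untouched.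

Compound 3 `COc1ccc(-n2cc(NC(=O)c3ccc(NS(=O)(=O)c4ccc(Cl)cc4)cc3)cn2)cc1` differs from compound 1 only there: chloro in place of hydrogen on an aromatic carbon. Going by the values given here, no measured pair bears on this change, so nothing points in either direction. For compound 3 the expected step is a 1.1-fold lower number from compound 1 to compound 3 (0.06 log units; within the scatter), an estimate that stays within the scatter. Compound 3 is accordingly estimated at 50000 nM in this assay, with a range from 18000 nM to 140000 nM.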

Compound 3, half-maximal inhibitory concentration: 19100 nM
Compound 3: the middle estimate sits 2.6-fold (0.42 log units) above what was measured, and the stated range covers the measured number.
By their numbers in this assay, from the lowest: compound 3; then compounds 1 and 2 (each within the scatter of the next).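

Going by these compounds alone, of the two sites changed so far, the aromatic ring on the sulfonyl side is the one where a single change carries beyond the scatter: in this assay, 4-chlorophenyl in place of phenyl gives a 3.0-fold lower number from compound 1 to compound 3 (0.48 log units; beyond the scatter). The earlier step on the methoxyphenyl stayed within the scatter, so the sulfonyl side is, on this one pair, the more responsive of the two. Nothing available explains the size or direction of this step.

From the compounds shown here alone, whether the lower number belongs to chloro in particular remains open, since a single substituent at this place cannot separate it from what fluoro, methyl, an amine or a carboxylic acid would give. Also open, going by these compounds, is whether the step carries over to the 3-methoxyphenyl series of compound 2.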